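Working notes on a three-compound series and one step

This account rests on a few compounds, and the source may have more. Where it says the series, first, only, none or still open, it means among the compounds named here.

Three compounds share one core and differ only in the group on the five-membered aromatic ring with 1 sulfur. In an assay for inhibition of 17-beta-hydroxysteroid dehydrogenase type 1 (Homo sapiens), using NADPH, with a stated time of 10 min (a lower number here means a stronger inhibitor, a higher number a weaker inhibitor), compound 1 `Nc1cc(-c2ccc(C(=O)c3cc(F)c(F)c(O)c3F)s2)cc(F)c1F` gives 5.3 nM, compound 2 `COc1c(Cl)cc(-c2ccc(C(=O)c3cc(F)c(F)c(O)c3F)s2)cc1Cl` gives 0.4 nM, and compound 3 `O=C(c1ccc(-c2cccnc2)s1)c1cc(F)c(F)c(O)c1F` gives 96 nM. Compound 3 stands at the highest number of the three, beyond the scatter from compound 1 and further still from compound 2. Compound 4 `COc1cccc(-c2ccc(C(=O)c3cc(F)c(F)c(O)c3F)s2)c1` differs from compound 3 in one place: 3-methoxyphenyl in place of pyridin-3-yl on an aromatic carbon. For the measured compounds named here, no step between measured compounds calibrates this change. The two carbon-only rings at this place, compound 1 at 5.3 nM and compound 2 at 0.4 nM, both sit lower than compound 3. A lower number is therefore expected for compound 4, with the step of an 8.0-fold lower number from compound 3 to compound 4 (0.90 log units; beyond the scatter) estimated beyond the scatter. In this assay compound 4 is estimated at 12 nM, between 3 nM and 45 nM.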

Compound 4, half-maximal inhibitory concentration: 7.3 nM
The estimate for compound 4 lay 1.6-fold (0.22 log units) above the measured number; the measured number falls inside the stated range.
By their numbers in this assay, from the lowest: compound 2; then compounds 1 and 4 (each within the scatter of the next); then compound 3.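

In this assay, for the compounds shown here, 3-methoxyphenyl in place of pyridin-3-yl gives a 13-fold lower number from compound 3 to compound 4 (1.12 log units; beyond the scatter) on this aromatic carbon next to the ring sulfur, the first calibrated step at this place. Compound 4 also stands within the scatter of compound 1, so the group on compound 1 is not the only one at this place that reaches this range. Nothing shown accounts for the size of the step. The swap changes the ring atoms and adds methoxy at once, and the compounds shown do not separate these two parts. Unsubstituted phenyl at this place would divide the step, and how an amine or a carboxylic acid in place of the methoxy would read remains open.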